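The compounds below may be only part of what the source reports. "The series", "measured", "known", "first", "only" and "open" are said of these compounds alone.

Measured so far in a functional assay on CHO cells for antagonist activity at prostaglandin E2 receptor EP1 subtype (Homo sapiens), read by FLIPR and calcium flux; on this read-out higher numbers stand for weaker inhibition and lower numbers for stronger inhibition:
compound 1 `CCc1ccccc1N(Cc1nnc(Cc2ccccc2)o1)S(=O)(=O)c1ccc(C)cc1` gives 398 nM
compound 2 `CCc1ccccc1N(Cc1nnc(Cc2ccc(Cl)cc2)o1)S(=O)(=O)c1ccc(C)cc1` gives 316 nM
compound 3 `CCc1ccccc1N(Cc1nnc(Oc2ccc(OC)cc2)o1)S(=O)(=O)c1ccc(C)cc1` gives 100 nM

Compound 3 stands lowest of the three numbers; its nearest neighbour is compound 2, with a 3.2-fold lower number from compound 2 to compound 3 (0.50 log units; beyond the scatter), and the furthest is compound 1, with a 4.0-fold lower number from compound 1 to compound 3 (0.60 log units; beyond the scatter). Compound 4 `CCc1ccccc1N(Cc1nnc(COc2ccc(OC)cc2)o1)S(=O)(=O)c1ccc(C)cc1` carries (4-methoxyphenoxy)methyl in place of 4-methoxyphenoxy on an aromatic carbon. Among the measured compounds shown here, no measured step isolates this change. For the measured compounds named here, the steps that bear on it are a 4.0-fold lower number from compound 1 to compound 3 (0.60 log units; beyond the scatter) and a 3.2-fold lower number from compound 2 to compound 3 (0.50 log units; beyond the scatter), where the benzyl and 4-chlorobenzyl groups gave higher numbers than the 4-methoxyphenoxy group of compound 3. The (4-methoxyphenoxy)methyl group of compound 4 shares features of both sides, so a modest rise, smaller than those steps, is expected. Compound 4 is estimated at 200 nM, with a range of 80 nM to 500 nM. The expected step is a 2.0-fold higher number from compound 3 to compound 4 (0.30 log units; within the scatter).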

Compound 4, inhibition constant: 126 nM
Beside the measured number, compound 4's estimate is 1.6-fold (0.20 log units) above it; the measured number falls inside the stated range.
By their numbers in this assay, from the lowest: compounds 3 and 4 (each within the scatter of the next); then compounds 2 and 1 (each within the scatter of the next).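

In this assay, (4-methoxyphenoxy)methyl and 4-methoxyphenoxy on this aromatic carbon cannot be told apart, with a 1.3-fold higher number from compound 3 to compound 4 (0.10 log units; within the scatter), so the position tolerates this change in the group's length. With the saturated chain carbon held in place, 4-methoxyphenoxy in place of 4-chlorophenyl gives a 2.5-fold lower number from compound 2 to compound 4 (0.40 log units; beyond the scatter), and in place of phenyl it gives a 3.2-fold lower number from compound 1 to compound 4 (0.50 log units; beyond the scatter), which places the difference in the group on that chain carbon. No evidence on the cause of these steps is at hand.

The compounds shown do not separate the ether oxygen from the methoxy on the terminal ring. On these data alone, how a longer chain at this position, or an amine in place of that methoxy, would read remains open.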